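Thiophene in Place of Fluorophenyl on a Guanidine Urea Series

The compounds below may be only part of what the source reports. "The series", "measured", "known", "first", "only" and "open" are said of these compounds alone.

Compound 1, `Cc1nc(N)sc1CCCN/C(N)=N/C(=O)NC(C)c1cccc(F)c1`, gives 2.04 nM in an assay on membranes from Sf9 cells for displacement of a labelled ligand from histamine H2 receptor (Homo sapiens), read by scintillation counting, with a stated time of 60 min (a higher number here means a weaker inhibitor, a lower number a stronger inhibitor), the lowest of the three numbers recorded. Compound 2, `Cc1nc(N)sc1CCCN/C(N)=N/C(=S)N[C@H](C)c1ccccc1`, gives 115 nM in this assay, and compound 3, `Cc1nc(N)sc1CCCN/C(N)=N/C(=O)NC(C)c1ccc(OC(F)(F)F)cc1`, gives 126 nM; both of these numbers sit well beyond the scatter above that of compound 1, so compound 1 is the strongest inhibitor among the three measured.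

The unmeasured compound 4, `Cc1nc(N)sc1CCCN/C(N)=N/C(=O)NC(C)c1cccs1`, differs from compound 1 in one place: thiophen-2-yl in place of 3-fluorophenyl on a saturated chain carbon bound to an amide-type nitrogen and a saturated chain carbon. A six-membered aromatic ring of carbon only gives way to a five-membered aromatic ring with one hetero atom, and the group entering is smaller by two heavy atoms.

Going by the values given here, no single-change pair among the measured compounds informs this step directly. Because compound 1 gives 2.04 nM, and the change is a swap of one aromatic ring for another of similar character, the step is expected to be small, toward a weaker inhibitor, and probably no further than the scatter: a 2.5-fold higher number from compound 1 to compound 4 (0.39 log units; beyond the scatter). Compound 4 is therefore estimated at 5 nM, within a range of 1.5 nM to 18 nM.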

Compound 4, inhibition constant: 63.1 nM
Compound 4: middle estimate off by 13-fold (1.10 log units), on the low side; measured number above the stated range.
By their numbers in this assay, from the lowest: compound 1; then compounds 4, 2 and 3 (each within the scatter of the next).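

The exchange of 3-fluorophenyl for thiophen-2-yl on this saturated chain carbon is not a minor swap of one aromatic ring for another: in this assay it gives a 31-fold higher number from compound 1 to compound 4 (1.49 log units; beyond the scatter) as a large step, beyond the scatter. Going by these compounds alone, this is the first single-change pair in the set, and it shows that the number at this position depends strongly on which aromatic ring is present, though only this one pair supports that reading. Nothing measured here accounts for the size of the step.

The change replaces the six-membered ring and removes the fluorine together, so the pair cannot separate the contribution of ring size from that of the fluorine. Going by these compounds, whether a pyridin-3-yl or thiophen-3-yl ring at this position would stay closer to compound 1 remains open.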